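This account rests on a few compounds, and the source may have more. Where it says the series, first, only, none or still open, it means among the compounds named here.

Measured in a functional assay on HT-29 cells (Homo sapiens) for cytotoxicity, read by sulforhodamine B assay, with a stated time of 2 days, tested at 100 uM; a lower number here means less inhibition, a higher number more inhibition at the concentration tested (going by the name of the read-out):
compound 1 `CCCc1n[nH]c2c(=O)n(NC(=O)c3ccccc3)c(-c3cccc([N+](=O)[O-])c3)nc12`: 18.7%
compound 2 `O=C(Nn1c(-c2cccc([N+](=O)[O-])c2)nc2c(-c3cccc(Cl)c3)n[nH]c2c1=O)c1ccccc1`: 89.8%
compound 3 `O=C(Nn1c(-c2cccc([N+](=O)[O-])c2)nc2c(-c3ccc(Cl)cc3)n[nH]c2c1=O)c1ccccc1`: 87.8%

Compound 3 stands second highest of the three numbers in this assay: its nearest neighbour is compound 2, separated by a number 2 percentage points lower from compound 2 to compound 3 (within the scatter), and its furthest is compound 1, separated by a number 69.1 percentage points higher from compound 1 to compound 3 (beyond the scatter). Compound 4 `O=C(Nn1c(-c2ccccc2)nc2c(-c3ccc(Cl)cc3)n[nH]c2c1=O)c1ccccc1` differs from compound 3 in one place: hydrogen in place of nitro on an aromatic carbon. Going by the values given here, no measured step touches the nitro; the two large steps, a number 71.1 percentage points higher from compound 1 to compound 2 (beyond the scatter) and a number 69.1 percentage points higher from compound 1 to compound 3 (beyond the scatter), both concern the group entering in place of propyl, and the only step among the chlorophenyl compounds, a number 2 percentage points lower from compound 2 to compound 3 (within the scatter), lies within the scatter. The measured steps therefore give no direction for this change, and a wide range is expected, centred a little below compound 3. Compound 4 is expected to give 72% (range 35% to 95%). The step expected is a number 15.8 percentage points lower from compound 3 to compound 4 (beyond the scatter).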

Compound 4, a percentage reported as inhibition, at one concentration (the size of the read-out at that concentration, not a potency): 92%
The estimate for compound 4 lay 20 percentage points below the measured number; the range from low to high includes it.
By their numbers in this assay, from the lowest: compound 1; then compounds 3, 2 and 4 (each within the scatter of the next).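

In this assay, the step for 3-nitrophenyl to phenyl reads a number 4.2 percentage points higher from compound 3 to compound 4 (within the scatter), so with 4-chlorophenyl on the shared core, the nitro is not needed for this level of inhibition. At this position, hydrogen serves as well as nitro at the single concentration tested. No measurement on hand accounts for this result.

Still open, going by these compounds, is whether the nitro is equally dispensable with propyl in place of 4-chlorophenyl, as in compound 1. Also open, on these data alone, is how an amine or a carboxylic acid on this aromatic carbon would read.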